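Exchanging One Halophenyl Group for Another

The compounds below may be only part of what the source reports. "The series", "measured", "known", "first", "only" and "open" are said of these compounds alone.

Measured compounds:
compound 1 `N=C(NCCCc1c[nH]cn1)NCCCC(c1ccc(F)cc1)c1ccccn1`: 46.8 nM
compound 2 `N=C(NCCCc1c[nH]cn1)NCCC(c1ccc(Cl)cc1)c1ccccn1`: 77.6 nM

In a functional assay on ileum for antagonist activity at histamine H1 receptor (Cavia porcellus) (on this read-out higher numbers stand for weaker binding and lower numbers for tighter binding), compound 1 gives 46.8 nM, and compound 2 gives 77.6 nM. Compound 2 carries the higher of the two numbers shown, but its gap to compound 1 lies within the scatter, so the two compounds cannot be ranked against each other.

Compound 3 `N=C(NCCCc1c[nH]cn1)NCCC(c1ccccn1)c1ccccc1F` has not yet been measured in this assay. It differs from compound 2 in one place: 2-fluorophenyl in place of 4-chlorophenyl on a saturated chain carbon bound to an aromatic carbon and a saturated chain carbon. Going by the values given here, no pair of measured compounds shows this exchange, and compound 1 and compound 2 differ in more than one way, so they give no direct guide. With nothing pointing either way, the step from compound 2 to compound 3 is expected to be a 1.3-fold higher number from compound 2 to compound 3 (0.11 log units; within the scatter), not beyond the scatter. Compound 3 is therefore estimated at 100 nM, with a range from 35 nM to 300 nM.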

Compound 3, dissociation constant: 437 nM
Beside the measured number, compound 3's estimate is 4.4-fold (0.64 log units) below it, outside the stated range (above it).
By their numbers in this assay, from the lowest: compounds 1 and 2 (each within the scatter of the next); then compound 3.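

In this assay putting 2-fluorophenyl in place of 4-chlorophenyl on a saturated chain carbon bound to an aromatic carbon and a saturated chain carbon gives a 5.6-fold higher number from compound 2 to compound 3 (0.75 log units; beyond the scatter) and so shows that this position does not treat these two halophenyl groups alike. The read-out moves beyond the scatter even though the two groups match in heavy-atom count and in their counts of hydrogen-bond donors and acceptors, and neither carries a net charge. Nothing measured here accounts for the size of this step.

The exchange changes both the halogen and its place on the ring, so the compounds shown cannot say which of the two matters. A 2-chlorophenyl group or a 4-fluorophenyl group on this same carbon would pull the two apart, and an unsubstituted phenyl group would show how either halogen compares with none.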